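The compounds below may be only part of what the source reports. "The series", "measured", "known", "first", "only" and "open" are said of these compounds alone.

Compound 1 `CCS(=O)(=O)Nc1ccc(C(C)C(=O)NCc2ccc(C(F)(F)F)nc2N2CCC(C)CC2)cc1F`: 4.4 nM
Compound 2 `CC1CCN(c2nc(C(F)(F)F)ccc2CNC(=O)C(C)c2ccc(NS(=O)(=O)C(C)C)c(F)c2)CC1`: 8.7 nM
Compound 3 `CC1CCN(c2nc(C(F)(F)F)ccc2CNC(=O)C(C)c2ccc(N(C)S(C)(=O)=O)c(F)c2)CC1`: 55.5 nM

In an assay on cells for antagonist activity at transient receptor potential cation channel subfamily V member 1 (Homo sapiens), read by FLIPR and calcium flux, with a stated time of 15 min (on this read-out higher numbers stand for weaker inhibition and lower numbers for stronger inhibition), compound 1 gives 4.4 nM, compound 2 gives 8.7 nM and compound 3 gives 55.5 nM. The change from compound 1 to compound 2 is methyl in place of hydrogen on a saturated chain carbon bound to a saturated chain carbon and a sulfonyl sulfur, and it made a step of a 2.0-fold higher number from compound 1 to compound 2 (0.30 log units; within the scatter). Compound 3 differs from compound 1 in the core, namely (methyl(methylsulfonyl)amino in place of (ethylsulfonyl)amino on an aromatic carbon), which went with a 13-fold higher number from compound 1 to compound 3 (1.10 log units; beyond the scatter) and also with a 6.4-fold higher number from compound 2 to compound 3 (0.80 log units; beyond the scatter). Compound 4 `CCN(c1ccc(C(C)C(=O)NCc2ccc(C(F)(F)F)nc2N2CCC(C)CC2)cc1F)S(C)(=O)=O` has not been measured yet. It differs from compound 3 by methyl in place of hydrogen on a saturated chain carbon bound to a sulfonamide nitrogen. This is the same kind of change as that from compound 1 to compound 2, but the place is different: a saturated chain carbon bound to a sulfonamide nitrogen, rather than one bound to a saturated chain carbon and a sulfonyl sulfur. Because the step of a 2.0-fold higher number from compound 1 to compound 2 (0.30 log units; within the scatter) lay within the scatter, compound 4 is expected to show a step of about a 1.4-fold higher number from compound 3 to compound 4 (0.16 log units; within the scatter) in this assay. Compound 4 is therefore estimated at 80 nM, with a likely range from 30 nM to 250 nM.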

Compound 4, inhibition constant: 22.7 nM
For compound 4 the middle estimate is 3.5-fold (0.55 log units) above the measured one, and the stated range ends above it.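

In this assay, the methyl did not carry over as a fixed step from one core to the other: the same change on two cores in this assay, a 2.0-fold higher number (0.30 log units; within the scatter) from compound 1 to compound 2 and a 2.4-fold lower number (0.39 log units; beyond the scatter) from compound 3 to compound 4, 4.8-fold (0.68 log units) apart, beyond the scatter of two such steps

On the sulfonamide nitrogen, the change gave a 2.4-fold lower number from compound 3 to compound 4 (0.39 log units; beyond the scatter), while the ethyl(methylsulfonyl)amino group still left a 2.6-fold higher number from compound 2 to compound 4 (0.42 log units; beyond the scatter) and a 5.2-fold higher number from compound 1 to compound 4 (0.71 log units; beyond the scatter). These two pairs show that the step depends on where the methyl sits or on the core that carries it, but they do not separate those two readings or explain the difference.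

The compounds shown leave open whether a longer chain on the sulfonamide nitrogen, such as propyl, would extend the step from methyl to ethyl. They also leave open how a propyl chain on the sulfonyl sulfur would compare.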